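Chloro in Place of Carbamoyl on the Aromatic Ring

The compounds below may be only part of what the source reports. "The series", "measured", "known", "first", "only" and "open" are said of these compounds alone.

Compound 1 `C=CC[C@H]1C[C@]2([C@@H](C)Cc3cccc(OC)c3)OCOC2=CC1=O` in a functional assay on M14 cells (Homo sapiens) for antiproliferative activity, with a stated time of 72 h; a lower number here means a stronger inhibitor, a higher number a weaker inhibitor: 8800 nM
Compound 2 `C=CC[C@H]1C[C@]2([C@@H](C)Cc3ccc(OC)c(C(N)=O)c3)OCOC2=CC1=O` in this assay: 12 nM
Compound 3 `C=CC[C@H]1C[C@]2(C(C)Cc3ccc(OC)c(OC(C)=O)c3)OCOC2=CC1=O` in this assay: 16 nM

Among the three measured compounds, compound 2 has the lowest number in this assay, but compound 3 lies within the scatter of it, so the two cannot be ordered. Compound 1, which carries its methoxy group without a neighbouring substituent, sits far above both, beyond the scatter.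

Compound 4 `C=CC[C@H]1C[C@]2([C@@H](C)Cc3ccc(OC)c(Cl)c3)OCOC2=CC1=O` has not been measured. It differs from compound 2 in one place: chloro in place of carbamoyl on an aromatic carbon. Among the measured compounds shown here, the single chlorine replaces a group that carried a hydrogen-bond donor and acceptor, while the methoxy group and the rest of the shared core are untouched.

For the measured compounds named here, no measured pair shows this change directly. Compound 4 is expected to give about 40 nM in this assay, with a range from 8 nM to 250 nM. The estimated step of a 3.3-fold higher number from compound 2 to compound 4 (0.52 log units; beyond the scatter) is a moderate rise, close to the edge of the scatter, because compound 3 gives 16 nM with a different group at the same place and stays low.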

Compound 4, half-maximal inhibitory concentration: 240 nM
The estimate for compound 4 lay 6.0-fold (0.78 log units) below the measured number; low and high end bracket the measured number.
By their numbers in this assay, from the lowest: compounds 2 and 3 (each within the scatter of the next); then compound 4; then compound 1.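

In this assay, among the compounds shown here, chloro in place of carbamoyl gives a 20-fold higher number from compound 2 to compound 4 (1.30 log units; beyond the scatter) and so provides the first direct reading at this position, where the earlier compounds offered no pair differing in one place. For the compounds shown here, with the methoxy group and the rest of the shared core unchanged, the group on this aromatic carbon clearly matters: the single swap produces a large step, well beyond the scatter. Nothing at hand explains why the number rises.

The compounds shown do not separate the loss of the hydrogen-bond donor from that of the acceptor, or either from the drop in heavy atoms, as chloro differs from carbamoyl in all three counts. As far as these compounds go, how a nitrile, an amine or a carboxylic acid would behave on this carbon also remains open.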